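The compounds below may be only part of what the source reports. "The series", "measured", "known", "first", "only" and "open" are said of these compounds alone.

Compound 1 `NNC(=O)CSc1nnc(-c2ccncc2)o1`, compound 2 `O=C(CSc1nnc(-c2ccncc2)o1)N/N=C/c1ccc([N+](=O)[O-])cc1` and compound 3 `COc1cccc(/C=N/NC(=O)CSc2nnc(-c3ccncc3)o2)c1` share one core and differ only at its far end. In a functional assay on MCF7 cells (Homo sapiens) for cytotoxicity, read by MTT assay, with a stated time of 48 h (on this read-out higher numbers stand for weaker inhibition and lower numbers for stronger inhibition), compound 1 gives 3260 nM, compound 2 gives 31800 nM and compound 3 gives 13800 nM. Compound 3 thus sits second highest of the three: the change from compound 2 to compound 3 gave a 2.3-fold lower number from compound 2 to compound 3 (0.36 log units; beyond the scatter), while compound 1 stays clearly lower than compound 3. Compound 4 `O=C(CSc1nnc(-c2ccncc2)o1)N/N=C/c1ccc(O)c(O)c1` carries the next change at the same position: 3,4-dihydroxyphenyl in place of 3-methoxyphenyl on a carbon with a double bond to nitrogen. Within the data shown here, the only step measured at this position was modest, so a modest step is expected for compound 4 too, its direction uncertain, estimated as a 1.5-fold lower number from compound 3 to compound 4 (0.19 log units; within the scatter). For compound 4 the expected value in this assay is 9000 nM, within a range from 3500 nM to 25000 nM.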

Compound 4, half-maximal inhibitory concentration: 910 nM
Compound 4: middle estimate off by 9.9-fold (1.00 log units), on the high side, and the stated range ends above it.
By their numbers in this assay, from the lowest: compound 4; then compound 1; then compound 3; then compound 2.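

At this position the group on the carbon with a double bond to nitrogen can shift the number far more than the earlier step suggested: in this assay 3,4-dihydroxyphenyl gives a 15-fold lower number from compound 3 to compound 4 (1.18 log units; beyond the scatter) and also a 35-fold lower number from compound 2 to compound 4 (1.54 log units; beyond the scatter). Before this, both compounds with a ring at this end stood above compound 1, whereas compound 4 at 910 nM stands below compound 1 at 3260 nM. Nothing given here explains this drop. The compounds shown leave open whether one hydroxyl group would do as well as two, and how an amine or a carboxylic acid on this ring would compare.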